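The source may report more compounds than this note shows. Statements on the series, on what has been measured and on what is new or still open speak of the compounds shown alone.

Measured in a functional assay on LNCaP cells (Homo sapiens) for antiproliferative activity; on this read-out lower numbers stand for stronger inhibition and higher numbers for weaker inhibition:
- compound 1 `CN1CCN(c2ccc(NC(=O)Nc3ccc(-c4nc(N5C6CCC5COC6)nc(N5[C@H](CO)CC[C@@H]5CO)n4)cc3)cc2)CC1`: < 0.8 nM (a limit of the assay)
- compound 2 `CC(C)Nc1nc(-c2ccc(NC(=O)Nc3ccc(N4CCN(C)CC4)cc3)cc2)nc(N2C3CCC2COC3)n1`: 50 nM
- compound 3 `CCN1CCN(c2ccc(NC(=O)Nc3ccc(-c4nc(C5CCOCC5)nc(N5C6CCC5COC6)n4)cc3)cc2)CC1`: < 0.8 nM (a limit of the assay)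

Compound 3 has no exact number and sits at the limit of < 0.8 nM in this assay, at which 2 of the 3 values shown sit. The next compound to be read is compound 4 `CN(C)C1CCN(C(=O)c2ccc(NC(=O)Nc3ccc(-c4nc(C5CCOCC5)nc(N5C6CCC5COC6)n4)cc3)cc2)CC1`. The structural change is (4-(dimethylamino)piperidin-1-yl)carbonyl in place of 4-ethylpiperazin-1-yl on an aromatic carbon. In words, (4-(dimethylamino)piperidin-1-yl)carbonyl stands in place of 4-ethylpiperazin-1-yl on an aromatic carbon of a six-membered aromatic ring of carbon only, para to a large group.

Among the compounds with values here, the only measured step is an at least 62-fold higher number from compound 1 to compound 2 (1.79 log units; beyond the scatter). It is large and beyond the scatter, but it replaces 2,5-bis(hydroxymethyl)pyrrolidin-1-yl with isopropylamino at a different place. It shows that this assay can respond strongly to a change elsewhere in the series, but it gives no size for this one. Within the data shown here, no measured step touches the group that changes here.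

The expectation therefore rests on compound 3 at < 0.8 nM, a limit of the assay, and only a modest move toward a higher number is anticipated. The expected size is an at least 1.8-fold higher number from compound 3 to compound 4 (0.27 log units; that floor lies within the scatter), and another reading at the limit remains possible. For compound 4 the estimated value is 1.5 nM, with an expected range of 0.4 nM to 8 nM.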

Compound 4, half-maximal inhibitory concentration: < 0.8 nM
Compound 4: no number, only a limit; the forecaster's own chance of this, stated with the estimate: 45%; middle value at least 1.8-fold (0.27 log units) away from the limit.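

In this assay compound 4 stands at < 0.8 nM, a limit and not a number; compound 3 stands at the same limit, and the step between the two cannot be read: the limit of < 0.8 nM in this assay, at which 3 of the 4 values shown sit.

The compounds shown leave open whether 4-ethylpiperazin-1-yl or (4-(dimethylamino)piperidin-1-yl)carbonyl gives the lower number in this assay, and by how much.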